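A few compounds are considered here, and "the series" means these few. Any claim that something is new, unique, unknown or untested is made for them only; others in the source may bear on it.

Measured in an assay on DDT1 cells (Cricetulus griseus) for binding affinity to adenosine receptor A1 (Homo sapiens), read by radioligand binding; a lower number here means a stronger inhibitor, a higher number a weaker inhibitor:
Compound 1 `CC/N=C(\S)OC[C@H]1OC(n2cnc3c(NC4CCOC4)ncnc32)[C@H](O)[C@@H]1O`: 33 nM
Compound 2 `CCCCNC(=O)OC[C@H]1OC(n2cnc3c(NC4CCOC4)ncnc32)[C@H](O)[C@@H]1O`: 1410 nM
Compound 3 `CC(C)/N=C(\S)OC[C@H]1OC(n2cnc3c(NC4CCOC4)ncnc32)[C@H](O)[C@@H]1O`: 36 nM

Compound 3 stands second highest of the three numbers. Its nearest neighbour is compound 1, a 1.1-fold higher number from compound 1 to compound 3 (0.04 log units; within the scatter), which falls within the scatter; its furthest is compound 2, a 39-fold lower number from compound 2 to compound 3 (1.59 log units; beyond the scatter). Compound 4 `O=C(NC1CC1)OC[C@H]1OC(n2cnc3c(NC4CCOC4)ncnc32)[C@H](O)[C@@H]1O` is not yet measured. It differs from compound 3 in one place: a group of 6 heavy atoms (4 carbon, 1 nitrogen, 1 oxygen; one three-membered non-aromatic ring of carbon only) in place of a group of 6 heavy atoms (4 carbon, 1 nitrogen, 1 sulfur; no ring), on an oxygen on a saturated carbon. The group that leaves carries sulfur, the group that enters carries oxygen and a three-membered ring. For the measured compounds named here, two measured steps bear on this exchange, each trading a sulfur-bearing group against an oxygen-bearing one on the same oxygen: a 43-fold higher number from compound 1 to compound 2 (1.63 log units; beyond the scatter) and a 39-fold lower number from compound 2 to compound 3 (1.59 log units; beyond the scatter). Both are large and both point the same way, the oxygen-bearing group standing at the higher number. Going by the values given here, no measured step covers the swap of a chain for a three-membered ring, but the step of a 1.1-fold higher number from compound 1 to compound 3 (0.04 log units; within the scatter), within the scatter, suggests the group on the nitrogen changes little here. A large rise in this assay is therefore expected, and for compound 4 the estimated step is a 33-fold higher number from compound 3 to compound 4 (1.52 log units; beyond the scatter). Compound 4 is expected to give about 1200 nM, within 350 nM to 4000 nM.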

Compound 4, inhibition constant: 209 nM
Estimate against measurement, compound 4: 5.7-fold (0.76 log units) above; measured number outside the range, below it.
By their numbers in this assay, from the lowest: compounds 1 and 3 (each within the scatter of the next); then compound 4; then compound 2.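

In this assay, for the compounds shown here, the group on the amide-type nitrogen matters among the oxygen-bearing groups, with cyclopropyl in place of butyl giving a clear gain (a 6.7-fold lower number from compound 2 to compound 4 (0.83 log units; beyond the scatter)), whereas the one change of this kind among the sulfur-bearing groups stayed within the scatter (a 1.1-fold higher number from compound 1 to compound 3 (0.04 log units; within the scatter)). Oxygen in place of sulfur on this oxygen on a saturated carbon therefore need not cost as much as the butyl compound indicated (a 43-fold higher number from compound 1 to compound 2 (1.63 log units; beyond the scatter)): with cyclopropylcarbamoyl the steps are only modest (a 5.8-fold higher number from compound 3 to compound 4 (0.76 log units; beyond the scatter); a 6.3-fold higher number from compound 1 to compound 4 (0.80 log units; beyond the scatter)). No measurement at hand accounts for the size of these steps.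

The compounds shown do not separate the exchange of sulfur for oxygen from the exchange of chain for ring, since no sulfur-bearing group with cyclopropyl is included. Going by these compounds, whether cyclobutyl or a propyl chain on the amide-type nitrogen would follow cyclopropyl or butyl remains open.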